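This account rests on a few compounds, and the source may have more. Where it says the series, first, only, none or still open, it means among the compounds named here.

- Compound 1 `CN1CCC(NS(=O)(=O)c2ccccc2Nc2cc(-c3ccc4ccn(C)c4c3)c3nccnc3c2)C1`: 26 ug/mL
- Compound 2 `CN(Cc1cncnc1)S(=O)(=O)c1ccccc1Nc1cc(-c2ccc3ccn(C)c3c2)c2nccnc2c1`: 3 ug/mL

In a physicochemical assay for solubility, read by spectrophotometry, measured as kinetic solubility, at pH 8, tested at 500 uM (a lower number here means a less soluble compound, a higher number a more soluble compound), compound 2 stands lowest of the two, at 3 ug/mL. Compound 3 `Cn1cc(CNS(=O)(=O)c2ccccc2Nc2cc(-c3ccc4ccn(C)c4c3)c3nccnc3c2)cn1` changes the group on the sulfonyl sulfur, with ((1-methyl-1H-pyrazol-4-yl)methyl)amino in place of methyl((pyrimidin-5-yl)methyl)amino on a sulfonyl sulfur.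

Within the data shown here, the only measured step at this place is an 8.7-fold lower number from compound 1 to compound 2 (0.94 log units; beyond the scatter). It is modest, but it leaves (1-methylpyrrolidin-3-yl)amino, a group that neither compound 2 nor compound 3 carries, so it is only an indirect guide. The leaving and entering groups both have no net charge, and each holds one aromatic ring with 2 hetero atoms. No step beyond the scatter is therefore expected in this assay. The estimated step is a 1.3-fold higher number from compound 2 to compound 3 (0.12 log units; within the scatter). For compound 3 the expected value is 4 ug/mL, with an estimated range of 1.5 ug/mL to 12 ug/mL.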

Compound 3, solubility: 2 ug/mL
The estimate for compound 3 lay 2.0-fold (0.30 log units) above the measured number, and the stated range covers the measured number.
By their numbers in this assay, from the lowest: compounds 3 and 2 (each within the scatter of the next); then compound 1.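

In this assay the change on the sulfonyl sulfur gives a 1.5-fold lower number from compound 2 to compound 3 (0.18 log units; within the scatter) and so stays within the scatter: at this place, the assay does not separate methyl((pyrimidin-5-yl)methyl)amino from ((1-methyl-1H-pyrazol-4-yl)methyl)amino, though their rings differ in size and only the latter carries a hydrogen-bond donor. On the sulfonamide nitrogen, (1-methyl-1H-pyrazol-4-yl)methyl in place of 1-methylpyrrolidin-3-yl gives a 13-fold lower number from compound 1 to compound 3 (1.11 log units; beyond the scatter) and is a large step, so compound 1 now stands apart from two compounds that each carry an aromatic ring in this group. The data offer no measured explanation for this result.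

As far as these compounds go, compound 1 alone carries 1-methylpyrrolidin-3-yl, so it remains open whether the higher number belongs to that particular group. From the compounds shown here alone, how a dimethylaminoethyl chain or a carboxylic acid at this place would read in this assay also remains open.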